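A few compounds are considered here, and "the series" means these few. Any claim that something is new, unique, unknown or untested is made for them only; others in the source may bear on it.

Compound 3 `CC[C@H](C)[C@H](N)CN(C(=O)[C@@H]1C[C@H]1c1ccccc1)c1ccc(-c2ccc(NS(C)(=O)=O)cc2)cc1` is the centre of this account, with its two companions compound 1 `CC[C@H](C)[C@H](N)CN(C(=O)[C@@H]1C[C@H]1c1ccccc1)c1ccc(-c2ccc(COC(C)(C)C)cc2)cc1` and compound 2 `CC[C@H](C)[C@H](N)CN(C(=O)[C@@H]1C[C@H]1c1ccccc1)c1ccc(-c2ccc(CCC(=O)OC)cc2)cc1`. In a functional assay for agonist activity at G protein-coupled receptor 88 (Homo sapiens), read by HTRF and cAMP accumulation (on this read-out higher numbers stand for an effect only at larger amounts of compound and lower numbers for an effect already at smaller amounts), compound 1 gives 280 nM, compound 2 gives 110 nM, and compound 3 gives 1200 nM. Compound 3 thus stands at the highest of the three numbers: the step of a 4.3-fold higher number from compound 1 to compound 3 (0.63 log units; beyond the scatter) and the step of an 11-fold higher number from compound 2 to compound 3 (1.04 log units; beyond the scatter) both run upward and both lie beyond the scatter, whereas the step of a 2.5-fold lower number from compound 1 to compound 2 (0.41 log units; beyond the scatter) is smaller. Compound 4 `CC[C@H](C)[C@H](N)CN(C(=O)[C@@H]1C[C@H]1c1ccccc1)c1ccc(-c2ccc(NC(C)=O)cc2)cc1` has not yet been measured. It differs from compound 3 by acetyl in place of methylsulfonyl on a nitrogen on an aromatic ring. Among the measured compounds shown here, none of the measured steps touches this nitrogen-bound group: all three exchange the whole substituent on the aromatic carbon, and the methanesulfonamido member, compound 3, gave the highest number among them. For the measured compounds named here, the exchange of methylsulfonyl for acetyl therefore has no direct precedent here. Compound 4 is expected to show a step of a 1.2-fold lower number from compound 3 to compound 4 (0.08 log units; within the scatter) that may well stay within the scatter in either direction. Compound 4 is accordingly estimated at 1000 nM in this assay, with a range from 350 nM to 3000 nM.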

Compound 4, half-maximal effective concentration: 5500 nM
Compound 4: middle estimate off by 5.5-fold (0.74 log units), on the low side; the whole stated range lies below it.
By their numbers in this assay, from the lowest: compound 2; then compound 1; then compound 3; then compound 4.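

In this assay the group held on the aromatic nitrogen proves to matter, since a 4.6-fold higher number from compound 3 to compound 4 (0.66 log units; beyond the scatter) follows from acetyl in place of methylsulfonyl, a change made with the nitrogen itself kept. Acetamido also widens the gap to the two substituents without this nitrogen, as a 50-fold higher number from compound 2 to compound 4 (1.70 log units; beyond the scatter) and a 20-fold higher number from compound 1 to compound 4 (1.29 log units; beyond the scatter) show, so among these four compounds both nitrogen-bound members carry higher numbers than compound 1 and compound 2, and compound 4 carries the highest. No measurement offered here accounts for the difference between acetyl and methylsulfonyl on this nitrogen.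

Going by these compounds, whether ethylsulfonyl or propanoyl on this nitrogen, or a free amine on the same aromatic carbon, would fall nearer compound 3 or compound 4 remains open. Also open, on these data alone, is how a carboxylic acid in place of the methyl ester of compound 2 would read.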